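Para-substituent swaps on the benzylsulfone catechol series

A few compounds are considered here, and "the series" means these few. Any claim that something is new, unique, unknown or untested is made for them only; others in the source may bear on it.

Working notes on a small set of vinyl sulfones sharing one catechol-bearing core. Compound 1 `O=S(=O)(/C=C/c1ccc(O)c(O)c1)Cc1ccc(Cl)cc1` gives 11700 nM in a functional assay on BV-2 cells (Mus musculus) for inhibition, read by Griess assay, with stated times of 3 h and 24 h (a lower number here means a stronger inhibitor, a higher number a weaker inhibitor), compound 2 `CC(C)(C)c1ccc(CS(=O)(=O)/C=C/c2ccc(O)c(O)c2)cc1` gives 12600 nM, and compound 3 `O=S(=O)(/C=C/c1ccc(O)c(O)c1)Cc1ccc(C(F)(F)F)cc1` gives 15900 nM. Compound 3 carries the highest of the three numbers, yet it stands close to both neighbours: the step of a 1.3-fold higher number from compound 2 to compound 3 (0.10 log units; within the scatter) and the step of a 1.4-fold higher number from compound 1 to compound 3 (0.13 log units; within the scatter) are each within the scatter, as is the step of a 1.1-fold higher number from compound 1 to compound 2 (0.03 log units; within the scatter). Across the three measured compounds, replacing one group on the benzylic ring with another has left the read-out essentially unchanged.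

Compound 4 `COc1ccc(CS(=O)(=O)/C=C/c2ccc(O)c(O)c2)cc1` is the next member, differing from compound 3 only as follows: methoxy in place of trifluoromethyl on an aromatic carbon. The three measured steps all bear on this change, since each exchanges the substituent at the same place, and none moved the number beyond the scatter. No larger effect is therefore expected here either. Compound 4 is estimated to give 13000 nM in this assay, with a plausible range from 6000 nM to 30000 nM. This estimate corresponds to a step of a 1.2-fold lower number from compound 3 to compound 4 (0.09 log units; within the scatter), expected to remain within the usual scatter of the series.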

Compound 4, half-maximal inhibitory concentration: 11900 nM
Compound 4: middle estimate off by 1.1-fold (0.04 log units), on the high side, and the stated range covers the measured number.
By their numbers in this assay, from the lowest: compounds 1, 4, 2 and 3 (each within the scatter of the next).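

Methoxy brings a hydrogen-bond acceptor to this aromatic carbon, para to a large group, where trifluoromethyl had none, and in this assay that exchange shows a 1.3-fold lower number from compound 3 to compound 4 (0.13 log units; within the scatter) even though the entering group also has fewer heavy atoms. The comparison with the other two groups reads the same way, with a 1.1-fold lower number from compound 2 to compound 4 (0.02 log units; within the scatter) for methoxy against tert-butyl and a 1.0-fold higher number from compound 1 to compound 4 (0.01 log units; within the scatter) for methoxy against chloro, so all four substituents now lie within the scatter of one another and the flat picture extends to a group with an acceptor. No measurement at hand explains this flat response or ties it to any property of the groups.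

Going by these compounds, whether a carboxylic acid, an amine, a hydroxyl or a longer chain such as hexyl at this place would move the number beyond the scatter remains open. On these data alone, all four compounds share the core of compound 1, so how far the read-out depends on that core, rather than on this substituent, also stays open.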